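This account rests on a few compounds, and the source may have more. Where it says the series, first, only, none or still open, it means among the compounds named here.

Measured set in a functional assay on HeLa cells (Homo sapiens) for cytotoxicity, read by CCK-8 assay, with a stated time of 72 h; a lower number here means a stronger inhibitor, a higher number a weaker inhibitor:
compound 1 `COc1ccccc1/C=c1\c(=O)[nH]/c(=C/c2ccccc2Cl)c(=O)n1C` gives 300 nM
compound 2 `C=CCn1c(=O)/c(=C\c2cccc(Br)c2)[nH]c(=O)/c1=C\c1ccccc1OC` gives 5400 nM
compound 3 `C=CCn1c(=O)/c(=C\c2cccc(Cl)c2)[nH]c(=O)/c1=C\c1ccccc1OC` gives 5500 nM

Compound 3 holds the highest number of the three. Compound 2 sits alongside it, a 1.0-fold higher number from compound 2 to compound 3 (0.01 log units; within the scatter), while compound 1 lies well lower, a gap beyond the scatter.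

Compound 4 `C=CCn1c(=O)/c(=C\c2ccccc2Cl)[nH]c(=O)/c1=C\c1ccccc1OC` differs from compound 3 by 2-chlorophenyl in place of 3-chlorophenyl on a double-bonded chain carbon bound to an aromatic carbon. Within the data shown here, the single measured step, a 1.0-fold higher number from compound 2 to compound 3 (0.01 log units; within the scatter), swaps one halogen for another and says nothing about where the halogen sits, so it does not bear on this change. Among the measured compounds shown here, compound 1 also carries a 2-chlorophenyl and in this assay gives 300 nM, but it differs from compound 4 elsewhere as well, so no direct step is available. Compound 4 is expected to give 1500 nM, between 350 nM and 6500 nM, an estimated step of a 3.7-fold lower number from compound 3 to compound 4 (0.56 log units; beyond the scatter) toward a lower number, with wide uncertainty.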

Compound 4, half-maximal inhibitory concentration: 5100 nM
For compound 4 the middle estimate is 3.4-fold (0.53 log units) below the measured one, and the stated range covers the measured number.
By their numbers in this assay, from the lowest: compound 1; then compounds 4, 2 and 3 (each within the scatter of the next).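

In this assay, 2-chlorophenyl in place of 3-chlorophenyl on the double-bonded chain carbon stays within the scatter (a 1.1-fold lower number from compound 3 to compound 4 (0.03 log units; within the scatter)), and so does 2-chlorophenyl in place of 3-bromophenyl (a 1.1-fold lower number from compound 2 to compound 4 (0.02 log units; within the scatter)); the three halogenated phenyl groups are not separated at this place. The 2-chlorophenyl of compound 4 does not by itself give a low number, since vinyl in place of hydrogen on the saturated chain carbon bound to an aromatic nitrogen is a large step (a 17-fold higher number from compound 1 to compound 4 (1.23 log units; beyond the scatter)). No available evidence explains this step.

Still open, on these data alone, is how a phenyl bearing an amine or a carboxylic acid would behave at the double-bonded chain carbon, and how a longer chain would behave in place of the vinyl.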